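The source may hold more compounds than are shown below. What is called first, only, known or untested is meant among the compounds shown, and "the series" means these compounds.

Measured so far in a functional assay on 8305C cells (Homo sapiens) for cytotoxicity, read by MTT assay, with a stated time of 24 h; a higher number here means a weaker inhibitor, a lower number a stronger inhibitor:
compound 1, `CCCCCc1ccc(-c2cn([C@H]3C[C@H](CO)N(C)O3)nn2)cc1`: 5960 nM
compound 2, `CN1O[C@@H](n2cc(-c3ccc(F)cc3)nn2)C[C@@H]1CO`: 6760 nM
compound 3, `CCCCCc1ccc(-c2cn([C@@H]3C[C@H](CO)N(C)O3)nn2)cc1`: 6240 nM

Compound 2 comes from compound 1 by fluoro in place of pentyl on an aromatic carbon, and this change gave a 1.1-fold higher number from compound 1 to compound 2 (0.05 log units; within the scatter). Compound 3 differs from compound 1 in one place only: the two compounds have the same atoms and bonds and differ only in configuration as drawn: 1 of 2 stereo elements differ; a stereocentre at a saturated ring carbon is drawn R in compound 1 and S in compound 3. That difference gave a 1.0-fold higher number from compound 1 to compound 3 (0.02 log units; within the scatter), which is what the fact that compounds 1 and 3 differ only in the configuration as drawn describes. Compound 4, `CN1O[C@H](n2cc(-c3ccc(F)cc3)nn2)C[C@@H]1CO`, has not yet been measured in this assay; it stands to compound 3 exactly as compound 2 stands to compound 1, the same change at the same place: fluoro in place of pentyl on an aromatic carbon. All three measured numbers lie within the scatter of one another, so the swap of pentyl for fluoro has so far left the read-out essentially unchanged. Compound 4 is expected to show a 1.1-fold higher number from compound 3 to compound 4 (0.05 log units; within the scatter) in this assay, matching the earlier step in size. The estimate for compound 4 is 7000 nM, with a range from 3500 nM to 14000 nM.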

Compound 4, half-maximal inhibitory concentration: 6850 nM
Estimate against measurement, compound 4: 1.0-fold (0.01 log units) above; the range from low to high includes it.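

In this assay, fluoro in place of pentyl on the core of compound 3 gave a 1.1-fold higher number from compound 3 to compound 4 (0.04 log units; within the scatter), and the stereocentre difference gave a 1.0-fold higher number from compound 2 to compound 4 (0.01 log units; within the scatter). The change therefore carries across these two cores with no difference in size that stands out from the scatter: the same change on two cores in this assay, a 1.1-fold higher number (0.05 log units; within the scatter) from compound 1 to compound 2 and a 1.1-fold higher number (0.04 log units; within the scatter) from compound 3 to compound 4, 1.0-fold (0.01 log units) apart, within the scatter of two such steps. Since neither step with this change is beyond the scatter, this shows only that it left the read-out essentially flat on both cores, not that a change with a clear effect would carry over in the same way.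

The compounds shown leave open whether an amine, a carboxylic acid or a longer chain in that place would move the number. They also leave open whether the other stereocentre matters.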